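The compounds below may be only part of what the source reports. "The series", "measured", "known", "first", "only" and "open" are said of these compounds alone.

Of the compounds shown here, two with a shared core have been tested in a functional assay on the whole organism (strain Wistar) for inhibition, with Rattus norvegicus as the target, read by paw edema, with stated times of 60 min and 6 h, at a dose of 100 mg/kg by the oral route; a lower number here means less inhibition, a higher number more inhibition at the dose given (going by the name of the read-out). Compound 1 `CCCCCCNC(=O)CC1CCc2cc(OC)c(OC)cc21` carries a hexylamino group on its carbonyl carbon, and in this assay compound 1 gives 38.3%. Compound 2 `COc1cc2c(cc1OC)C(CC(=O)N1CCNCC1)CC2` carries a piperazin-1-yl group at the same place, and in this assay compound 2 gives 33.3%. The step of a number 5 percentage points lower from compound 1 to compound 2 (within the scatter) shows that swapping these two groups left the number essentially unchanged, so compound 2 stands alongside compound 1 rather than apart from it.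

Compound 3 `COc1cc2c(cc1OC)C(CC(=O)NCCO)CC2` is not yet measured. It differs from compound 2 by (2-hydroxyethyl)amino in place of piperazin-1-yl on a carbonyl carbon.

Going by the values given here, only one measured step bears on this change: the exchange of one amide substituent for another on the same carbonyl carbon, a number 5 percentage points lower from compound 1 to compound 2 (within the scatter), which stayed within the scatter. Compound 3 is therefore expected to move by about a number 1.7 percentage points higher from compound 2 to compound 3 (within the scatter), that is, nothing beyond the scatter in either direction. The estimate for compound 3 is 35%, with a range from 20% to 50%.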

Compound 3, a percentage reported as inhibition, in the whole organism at one dose (the size of the read-out at that dose, not a potency): 13%
The estimate for compound 3 lay 22 percentage points above the measured number; measured number outside the range, below it.
By their numbers in this assay, from the lowest: compound 3; then compounds 2 and 1 (each within the scatter of the next).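

In this assay, the group on this carbonyl carbon proves able to change the number: (2-hydroxyethyl)amino in place of piperazin-1-yl gives a number 20.3 percentage points lower from compound 2 to compound 3 (beyond the scatter) and so departs from the earlier exchange of hexylamino for piperazin-1-yl, which stayed within the scatter. Hydroxy in place of butyl on a saturated chain carbon, two bonds along the chain from an amide-type nitrogen, gives a number 25.3 percentage points lower from compound 1 to compound 3 (beyond the scatter) and points the same way. Among these three amides, then, the ring and the longer chain stand together, while the short hydroxy-bearing chain stands apart from both.

On these data alone, whether the hydroxy group or the shorter chain matters more stays open, and a plain ethylamino group or a methoxy group at the chain end could help separate the two. Nothing available explains this drop.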